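Fluoro for Chloro in a Pair of Cytotoxic Compounds

The source may report more compounds than this note shows. Statements on the series, on what has been measured and on what is new or still open speak of the compounds shown alone.

Compound 1 `C/C(=N/NC(=S)Nc1ccccc1F)c1ccccn1`: 5 nM
Compound 2 `C/C(=N\NC(=S)Nc1ccccc1Cl)c1ccccn1`: 2.6 nM

Both compounds were tested in a functional assay on U-87MG ATCC cells (Homo sapiens) for cytotoxicity, read by MTT assay, with a stated time of 48 h; a lower number here means a stronger inhibitor, a higher number a weaker inhibitor. There, compound 2 gives 2.6 nM, which lies within the scatter of compound 1 at 5 nM, so the two numbers cannot be ranked against each other.

Compound 3 `C/C(=N\NC(=S)Nc1ccccc1F)c1ccccn1` has not yet been measured. It differs from compound 2 by having fluoro in place of chloro on an aromatic carbon, ortho to a large group: fluoro in place of chloro on an aromatic carbon. Within the data shown here, no measured pair isolates a single structural change, so the data give no direct size for this exchange. The expectation leans instead on compound 1, which also carries a fluoro group and gives 5 nM. In this assay, no shift beyond the scatter is expected. The estimated step is a 1.5-fold higher number from compound 2 to compound 3 (0.19 log units; within the scatter), and it is expected to be small. Compound 3 is expected at 4 nM, with an estimated range of 1.5 nM to 11 nM.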

Compound 3, half-maximal inhibitory concentration: 5 nM
The estimate for compound 3 lay 1.3-fold (0.10 log units) below the measured number; the range from low to high includes it.
By their numbers in this assay, from the lowest: compounds 2, 1 and 3 (each within the scatter of the next).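

In this assay, among these compounds, the exchange of chloro for fluoro on an aromatic carbon, ortho to a large group, now has a directly measured size, which the earlier compounds could not give: a 1.9-fold higher number from compound 2 to compound 3 (0.28 log units; within the scatter). At this position, then, the two halogens cannot be told apart in this cell assay, and the pair gives no ranking of one over the other. The result also supplies the first comparison that isolates the configuration of the double bond, no change at the digits printed from compound 1 to compound 3 (within the scatter), so the configuration as drawn makes no difference that these numbers can resolve, and the gap between the first two compounds cannot be assigned to either of the two places in which they differ, as the new pair shows for one of them: the fact that compounds 1 and 3 differ only in the configuration as drawn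

The compounds shown leave open whether a group of another kind at this position, such as an amine, a methoxy group or a carboxylic acid, would move the number beyond the scatter. Among the compounds shown here, they also leave open whether configuration behaves in the same way with chloro on the ring, as the one pair that isolates it carries fluoro.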